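A few compounds are considered here, and "the series" means these few. Any claim that something is new, unique, unknown or untested is made for them only; others in the source may bear on it.

In an ADME assay on CCRF-HSB-2 cells (Homo sapiens) for cytotoxicity, with a stated time of 7 days (on this read-out higher numbers stand for lower toxicity in this test and lower numbers for higher toxicity in this test), compound 1 (`CCCSc1nc(N)nc2c1ncn2/C=C1/CC1(CO)CO`) gives 98000 nM. Compound 2 (`CC(C)CNc1nc(N)nc2c1ncn2/C=C1/CC1(CO)CO`) gives > 20000 nM, which is a limit of the assay and not a number. Among the measured compounds shown here, the only measured step is a step that the limit leaves unreadable from compound 1 to compound 2, so it offers neither a size nor a direction. Compound 3 (`CCCOc1nc(N)nc2c1ncn2/C=C1/CC1(CO)CO`) differs from compound 2 by a single change, propoxy in place of isobutylamino on an aromatic carbon. For the measured compounds named here, no measured step covers this exchange. Going by the values given here, the expectation therefore rests loosely on compound 1, which carries propylsulfanyl in that place and has the only exact reading, 98000 nM. In this assay, compound 3 is expected to stay in the same high range, with no clear direction from compound 2. The expected step is a step that the limit leaves unreadable from compound 2 to compound 3. For compound 3, the estimate is 60000 nM, with an expected range from 20000 nM to 180000 nM.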

Compound 3, half-maximal cytotoxic concentration: > 20000 nM
Compound 3: a limit, no number (the forecaster's own chance of this, stated with the estimate: 50%); the middle value does not contradict the limit.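

Compound 3, like compound 2, gives only a limit and not a number in this assay, so no step can be read from compound 2 to compound 3 or from compound 1 to compound 3: the limit of > 20000 nM in this assay, at which 2 of the 3 values shown sit. The compounds shown leave open how propoxy, isobutylamino and propylsulfanyl compare on the shared core.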